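The source may report more compounds than this note shows. Statements on the series, on what has been measured and on what is new or still open speak of the compounds shown alone.

Compounds measured so far:
compound 1, `O=c1c([C@@H]2C[C@H](c3ccccc3)ON2c2ccccc2)coc2ccc(F)cc12` — 60000 nM
compound 2, `COC(=O)[C@@]1(C)C[C@@H](c2coc3ccc(F)cc3c2=O)N(c2ccccc2)O1` — 29500 nM
compound 3, `O=c1c([C@@H]2C[C@H](c3ccccc3)ON2c2ccccc2)coc2cc(Cl)c(Cl)cc12` — 23500 nM

All three were run in a functional assay on Caco-2 cells (Homo sapiens) for inhibition, read by sulforhodamine B assay, with a stated time of 48 h; on this read-out higher numbers stand for weaker inhibition and lower numbers for stronger inhibition. Compound 1 gives the highest of the three numbers; the nearest is compound 2 and the furthest is compound 3, and both gaps lie beyond the usual scatter. No two of these compounds differ in only one place, so no single step between measured compounds can be read off.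

Compound 4, `O=c1c([C@@H]2C[C@H](c3ccccc3)ON2c2ccccc2)coc2ccccc12`, is the next compound. It differs from compound 1 by hydrogen in place of fluoro on an aromatic carbon. Going by the values given here, no measured pair shows what this change does on the shared core, so the expectation rests on compound 1 alone, with its 60000 nM as the anchor. The step of a 1.1-fold higher number from compound 1 to compound 4 (0.03 log units; within the scatter) is expected to be small, with no direction beyond the scatter. For compound 4 the estimate is 65000 nM, in the range 30000 nM to 140000 nM.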

Compound 4, half-maximal inhibitory concentration: > 60000 nM
Compound 4 was reported as a limit (the forecaster's own chance of this, stated with the estimate: 20%); the middle value does not contradict the limit.
By their numbers in this assay, from the lowest: compounds 3 and 2 (each within the scatter of the next); then compound 1.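

Hydrogen in place of fluoro on the aromatic carbon gives the first single-place step in the series: a number no lower from compound 1 to compound 4 (the limit leaves the size open) in this assay. On the shared core, then, this change brings no lower number, so hydrogen at this position does not strengthen inhibition. Compound 4 carries a limit and not a number: the limit of > 60000 nM in this assay, at which 1 of the 4 values shown sits.

On these data alone, how far the number rises, if at all, stays open, so any contribution of the fluoro group cannot be sized. Also open, as far as these compounds go, is what an amine or a methoxy group at this position would do on the shared core.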